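Trimming the benzyl amide of a compound with a modest inhibition number

The source may report more compounds than this note shows. Statements on the series, on what has been measured and on what is new or still open speak of the compounds shown alone.

Compound 1 `CC(C)(C)OC(=O)NCCCCCN1C(Nc2ccc(-c3ccccc3)cc2)=Nc2ccccc2C1CC(=O)NCc1ccccc1`: 30.1%
Compound 2 `NCCCCCNC1=Nc2ccccc2C(CC(=O)NCc2ccccc2)N1c1ccc(-c2ccccc2)cc1`: 8.3%

Of the compounds shown here, two have been measured in an assay on HEK293 cells for inhibition of Voltage-dependent N-type calcium channel subunit alpha-1B (Homo sapiens), tested at 10 uM; a higher number here means more inhibition at the concentration tested (going by the name of the read-out), a lower number less inhibition. Compound 1 gives 30.1%, the higher of the two numbers, while compound 2 gives 8.3%, which lies below compound 1 by more than the usual scatter. Going by the values given here, no pair differing in a single place has been measured, so these values only show that compound 1 stands at the top of this small set.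

Compound 3 `COC(=O)CC1c2ccccc2N=C(Nc2ccc(-c3ccccc3)cc2)N1CCCCCNC(=O)OC(C)(C)C` has not yet been measured. It differs from compound 1 in one place: methoxy in place of benzylamino on a carbonyl carbon. The benzylcarbamoyl group of compound 1 thus becomes a methoxycarbonyl group.

Among the compounds with values here, with no measured step of this kind available, the expectation rests on the modest value of compound 1 alone. In this assay the expected step is a number 12.1 percentage points lower from compound 1 to compound 3 (beyond the scatter), downward and possibly beyond the scatter. Compound 3 is therefore estimated at 18%, within a range from 0% to 38%.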

Compound 3, a percentage reported as inhibition, at one concentration (the size of the read-out at that concentration, not a potency): 94.9%
For compound 3 the middle estimate is 76.9 percentage points below the measured one, and the stated range ends below it.
By their numbers in this assay, from the lowest: compound 2; then compound 1; then compound 3.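

Going by these compounds alone, on the carbonyl carbon whose other neighbour is a saturated chain carbon, exchanging benzylamino for methoxy gives the first single-place step in this assay: a number 64.8 percentage points higher from compound 1 to compound 3 (beyond the scatter). In this pair, the benzylamino group with its aromatic ring and amide hydrogen is therefore not required for inhibition at the concentration tested, and the methoxycarbonyl group, with no ring, gives the higher number. Nothing measured here accounts for the size of this step.

Going by these compounds, it remains open whether the gain depends on the methyl ester itself or follows from removing the benzylamino group, a question that a carboxylic acid, a primary amide or an ethyl ester on this carbonyl could help to settle. Also open, on these data alone, is whether a smaller amide, such as the methyl amide, would keep the higher number.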